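The source may report more compounds than this note shows. Statements on the series, on what has been measured and on what is new or still open speak of the compounds shown alone.

Series notes on an assay (Equus caballus) for inhibition of Thromboxane-A synthase (Homo sapiens), using microsomes; a higher number here means a weaker inhibitor, a lower number a stronger inhibitor. Compound 2 `O=C(O)CCCC/C=C(\c1cccnc1)c1cccc(F)c1` gives 55 nM in this assay. Compound 1 `Cc1ccsc1/C(=C/CCCCC(=O)O)c1cccnc1` gives 29 nM, and compound 3 `C/C(=C\CCCCC(=O)O)c1cccnc1` gives 210 nM. Among these three numbers compound 2 stands second highest: the step of a 1.9-fold higher number from compound 1 to compound 2 (0.28 log units; within the scatter) is within the scatter, whereas the gap between compound 3 and compound 2 lies beyond it.

Compound 4 `O=C(O)CCCC/C=C(/c1ccc(F)cc1)c1cccnc1` is not yet measured. It differs from compound 2 in one respect: 4-fluorophenyl in place of 3-fluorophenyl on a double-bonded chain carbon bound to an aromatic carbon and a double-bonded chain carbon. Among the compounds with values here, no measured step exchanges 3-fluorophenyl for 4-fluorophenyl. Within the data shown here, the only step measured on the same double-bonded chain carbon, a 1.9-fold higher number from compound 1 to compound 2 (0.28 log units; within the scatter), replaces the whole aryl group and still stays within the scatter, and the larger gap in this assay is the one between compound 3 and compound 2, which does not involve a fluorophenyl group at all. The change from compound 2 to compound 4 is accordingly expected to give no step beyond the scatter. The expected change is no change at the digits printed from compound 2 to compound 4 (within the scatter), within the scatter. Compound 4 is estimated at 55 nM in this assay, with a range from 20 nM to 150 nM.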

Compound 4, half-maximal inhibitory concentration: 83 nM
The estimate for compound 4 lay 1.5-fold (0.18 log units) below the measured number; low and high end bracket the measured number.
By their numbers in this assay, from the lowest: compounds 1, 2 and 4 (each within the scatter of the next, the first and the last beyond it); then compound 3.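

In this assay, within the data shown here, 4-fluorophenyl in place of 3-fluorophenyl on the double-bonded chain carbon gives a 1.5-fold higher number from compound 2 to compound 4 (0.18 log units; within the scatter), the first exchange at this position that keeps the fluorophenyl group, and it is not resolved from the scatter. The same position now also gives its first aryl exchange beyond the scatter, a modest 2.9-fold higher number from compound 1 to compound 4 (0.46 log units; beyond the scatter), whereas the exchange of the same 3-methylthiophen-2-yl group for 3-fluorophenyl gives only a 1.9-fold higher number from compound 1 to compound 2 (0.28 log units; within the scatter). No measurement shown bears on the origin of these steps.

Still open, going by these compounds, is whether an unsubstituted phenyl or a 4-methoxyphenyl group on this carbon would separate from either fluorophenyl compound beyond the scatter. Also open, on these data alone, is whether these small aryl steps would persist with a longer chain carrying the carboxylic acid.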